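Sulfonamide series: step from compound 2 to compound 4

A few compounds are considered here, and "the series" means these few. Any claim that something is new, unique, unknown or untested is made for them only; others in the source may bear on it.

Measured so far in an assay on cells for inhibition of Amine oxidase [flavin-containing] B (Homo sapiens), read by fluorescence and spectrophotometry, using microsomes, with a stated time of 20 min; on this read-out higher numbers stand for weaker inhibition and lower numbers for stronger inhibition:
compound 1 `NS(=O)(=O)c1cccc(-c2nnc(-c3ccc(F)cc3)o2)c1`: 975 nM
compound 2 `NS(=O)(=O)c1ccc(C(=O)NNC(=O)c2ccc(Cl)c(Cl)c2)cc1`: 10100 nM
compound 3 `NS(=O)(=O)c1ccc(-c2nnc(-c3ccc(Cl)c(Cl)c3)o2)cc1`: 2.7 nM

Compound 2 holds the highest of the three numbers, beyond the scatter from compound 1 and far beyond it from compound 3, so it is the weakest inhibitor measured here. Compound 4 `NS(=O)(=O)c1ccc(C(=O)NNC(=O)c2ccc(F)cc2)cc1` differs from compound 2 in one place: 4-fluorophenyl in place of 3,4-dichlorophenyl on a carbonyl carbon. Going by the values given here, no measured pair covers this exchange on the hydrazide core. Compounds 1 and 3 carry the same two aryl groups on a different core, and there the 4-fluorophenyl compound 1 gives a far higher number than the 3,4-dichlorophenyl compound 3. The step is therefore expected to weaken inhibition, clearly beyond the scatter: a 4.0-fold higher number from compound 2 to compound 4 (0.60 log units; beyond the scatter). For compound 4 the estimate in this assay is 40000 nM, with a range from 10000 nM to 160000 nM.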

Compound 4, half-maximal inhibitory concentration: > 100000 nM
Compound 4: only a limit was reported; the forecaster's own chance of this, stated with the estimate: 35%; middle value at least 2.5-fold (0.39 log units) from the limit.
By their numbers in this assay, from the lowest: compound 3; then compound 1; then compound 2. At a limit, above all of these: compound 4.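

In this assay, compound 4 reaches only a limit, > 100000 nM. Going by these compounds alone, putting 4-fluorophenyl in place of 3,4-dichlorophenyl on this carbonyl carbon gives an at least 9.9-fold higher number from compound 2 to compound 4 (0.99 log units; beyond the scatter), the first direct reading of this exchange on a single core. The position therefore does not keep its inhibition through this change, and the full size of the step stays unresolved.

Still open, on these data alone, is whether the step follows the loss of the chlorines or the entry of the fluorine. An unsubstituted phenyl or a 4-chlorophenyl on this carbonyl carbon would separate the two.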